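Swapping an Open Carbamate Chain for a Hydroxyethyl Piperidine

The source may hold more compounds than are shown below. What is called first, only, known or untested is meant among the compounds shown, and "the series" means these compounds.

The series is followed in an assay on HEK293 cells for displacement of a labelled ligand from NPC1-like intracellular cholesterol transporter 1 (Homo sapiens); on this read-out higher numbers stand for weaker inhibition and lower numbers for stronger inhibition. Compound 1 `CC(C)(C)OC(=O)NCCNC(=O)CN1CN(c2ccccc2)C2(CCN(C(=O)c3ccc(C(C)(C)C)cc3)CC2)C1=O` gives 10900 nM there, the higher of the two numbers recorded so far. Compound 2 `CC(C)(C)OC(=O)NC1CCCN(C(=O)CN2CN(c3ccccc3)C3(CCN(C(=O)c4ccc(C(C)(C)C)cc4)CC3)C2=O)C1` gives 4200 nM in this assay, and the gap between compound 1 and compound 2 lies beyond the usual scatter. The new compound 3 `CC(C)(C)c1ccc(C(=O)N2CCC3(CC2)C(=O)N(CC(=O)N2CCCCC2CCO)CN3c2ccccc2)cc1` arises from compound 1 through the change (2-(2-hydroxyethyl)piperidin-1-yl in place of (2-((tert-butoxycarbonyl)amino)ethyl)amino on a carbonyl carbon). Going by the values given here, no measured pair shows exactly this exchange, so the expectation for compound 3 rests on the two values alone. Since compound 2, with its cyclic amide substituent, sits at 4200 nM, a modest drop in the number is expected from compound 1 to compound 3, of about a 2.4-fold lower number from compound 1 to compound 3 (0.38 log units; beyond the scatter). Compound 3 is therefore estimated at 4500 nM in this assay, with a likely range from 1500 nM to 13000 nM.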

Compound 3, half-maximal inhibitory concentration: 6100 nM
Compound 3: middle estimate off by 1.4-fold (0.13 log units), on the low side, within the range that was stated.
By their numbers in this assay, from the lowest: compounds 2, 3 and 1 (each within the scatter of the next, the first and the last beyond it).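

In this assay, exchanging the open chain for the piperidine group gives a 1.8-fold lower number from compound 1 to compound 3 (0.25 log units; within the scatter), and this step lies within the usual scatter, so the read-out does not separate the two compounds. The position thus accepts a marked change in substituent without a measurable shift: the open chain with its tert-butoxycarbonyl group leaves, and a six-membered non-aromatic ring with one hetero atom enters, with fewer hydrogen-bond donors and acceptors. Nothing available explains this outcome.

As far as these compounds go, it remains open whether a free amine or a carboxylic acid at this position would move the number beyond the scatter. Also open, from the compounds shown here alone, is how a longer chain in place of the 2-hydroxyethyl group would read out.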